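Chloro on the pyridine: a single-point lipophilicity step

This account rests on a few compounds, and the source may have more. Where it says the series, first, only, none or still open, it means among the compounds named here.

For the measured compounds named here, compound 2 `Cc1c(CNC2CCCC2)nn(-c2ncccc2Cl)c1-c1cccnc1` is the one compound of this small pair with a numerical reading in a physicochemical assay for lipophilicity, using the shake flask method, at pH 7.4 (on this read-out lower numbers stand for lower lipophilicity and higher numbers for higher lipophilicity), where compound 2 gives 1.3. Compound 1 `Cc1c(CNC2CCCC2)nn(-c2ccc(Cl)cc2Cl)c1-c1ccc(Cl)cc1` returns only a limit in this assay, > 4, so its true value is not known. The evidence from the measured compounds is therefore thin: the limit of > 4 in this assay, at which 1 of the 2 values shown sits. Compound 3 `Cc1c(CNC2CCCC2)nn(-c2ncccc2Cl)c1-c1ccc(Cl)nc1` has not yet been measured. It differs from compound 2 by chloro in place of hydrogen on an aromatic carbon. Going by the values given here, no step between two measured compounds is available to size this change, so the expectation rests on the change alone. A moderate rise in this assay is expected, beyond the usual scatter yet well short of the limit, and the expected step is a number 0.70 log units higher from compound 2 to compound 3 (beyond the scatter). Compound 3 is accordingly estimated at 2, with a likely range from 1.5 to 2.6.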

Compound 3, distribution coefficient: 2.1
For compound 3 the middle estimate is 0.10 log units below the measured one; low and high end bracket the measured number.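

The change from pyridin-3-yl to 6-chloropyridin-3-yl now has a size in this assay: chloro in place of hydrogen, on the aromatic carbon next to the ring nitrogen and para to a large group, reads as a number 0.80 log units higher from compound 2 to compound 3 (beyond the scatter). The earlier compounds shown here gave no such step, as compound 1 carries only a limit and differs from compound 2 in more than one place. Nothing measured here accounts for the size of this step.

On these data alone, whether fluoro, methyl or methoxy on the same carbon would give a step of similar size remains open. As far as these compounds go, it is also open whether chloro on another carbon of the pyridin-3-yl ring would match this step.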